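A few compounds are considered here, and "the series" means these few. Any claim that something is new, unique, unknown or untested is made for them only; others in the source may bear on it.

Working notes on the series. Of the compounds shown here, three have been measured in a functional assay on NCI-H520 cells (Homo sapiens) for inhibition, read by MTT assay, with a stated time of 48 h, tested at 10 uM; on this read-out higher numbers stand for more inhibition at the one concentration tested (going by the name of the read-out) and lower numbers for less inhibition. Compound 1, `COc1cc(NC(=O)Nc2cc(Nc3ccc(C)c(F)c3)ncn2)cc(OC)c1`, gives 30.6% in this assay. Compound 2, `COc1ccc(C(F)(F)F)cc1Nc1cc(NC(=O)Nc2c(Cl)cccc2Cl)ncn1`, gives 33%, and compound 3, `COc1cc(Nc2cc(NC(=O)Nc3c(Cl)cccc3Cl)ncn2)cc(C(F)(F)F)c1`, gives 23.1%. All three numbers lie within the usual scatter of one another, so no ordering among them is supported; compound 1 sits among them with a number that differs from compound 2 and from compound 3 by less than the scatter allows to count.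

Compound 4, `COc1cc(NC(=O)Nc2cc(Nc3ccc(OC)c(C)c3)ncn2)cc(OC)c1`, has not been measured. It differs from compound 1 in one place: 4-methoxy-3-methylphenyl in place of 3-fluoro-4-methylphenyl on a nitrogen on an aromatic ring. For the measured compounds named here, no measured pair shows this change, so nothing in the data speaks for a step beyond the scatter. The step from compound 1 to compound 4 is therefore expected to be small, a number 0.6 percentage points lower from compound 1 to compound 4 (within the scatter), with no direction favoured. For compound 4 a value of 30% is estimated in this assay, with a range from 18% to 42%.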

Compound 4, a percentage reported as inhibition, at one concentration (the size of the read-out at that concentration, not a potency): 13.5%
Beside the measured number, compound 4's estimate is 16.5 percentage points above it, and the stated range ends above it.
By their numbers in this assay, from the lowest: compounds 4, 3, 1 and 2 (each within the scatter of the next, the first and the last beyond it).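

In this assay, the exchange of 3-fluoro-4-methylphenyl for 4-methoxy-3-methylphenyl on a nitrogen on an aromatic ring gives a number 17.1 percentage points lower from compound 1 to compound 4 (beyond the scatter) and provides the first step read at this position. The earlier compounds shown here included no pair differing in one place, so only now is there a sign that the group on this nitrogen can alter the inhibition seen at the one concentration tested. No evidence at hand bears on what lies behind this step.

The exchange removes fluorine and brings in a methoxy group together, so the compounds shown do not separate the two. Also open, going by these compounds, is how the read-out responds to a morpholine or a carboxylic acid on the ring carried by this nitrogen.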